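Benzyl exchange: compound 2 to compound 4

This account rests on a few compounds, and the source may have more. Where it says the series, first, only, none or still open, it means among the compounds named here.

- compound 1 `COc1cc(N)c(Cl)cc1C(=O)NCCN(C)C(C)c1ccccc1`: 1 mg/kg
- compound 2 `CCN(CCNC(=O)c1cc(Cl)c(N)cc1OC)Cc1cccc(OC)c1`: 1 mg/kg
- compound 3 `CCN(CCNC(=O)c1cc(Cl)c(N)cc1OC)Cc1ccc(OC)cc1`: 0.2 mg/kg

In a functional assay on the whole organism with Rattus norvegicus as the target (a higher number here means that more compound is needed for the effect, a lower number that less compound is needed), compound 2 stands at 1 mg/kg, level with compound 1 at 1 mg/kg, and these two share the highest number of the three. Compound 4 `CCN(CCNC(=O)c1cc(Cl)c(N)cc1OC)Cc1ccc(F)cc1` is the next compound in view, and it differs from compound 2 as follows: 4-fluorophenyl in place of 3-methoxyphenyl on a saturated chain carbon bound to an amine nitrogen. The same difference, cut one bond further out, reads 3-methoxybenzyl to 4-fluorobenzyl.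

Going by the values given here, only one measured step bears on this change: a 5.0-fold lower number from compound 2 to compound 3 (0.70 log units; beyond the scatter), with 4-methoxyphenyl in place of 3-methoxyphenyl at the same place. Among the compounds with values here, that step is beyond the scatter, but no measured compound carries 4-fluorophenyl, so its size transfers only loosely. Given compound 3 at 0.2 mg/kg, a lower number in this assay is expected, probably a smaller drop than that one. The estimated step is a 2.5-fold lower number from compound 2 to compound 4 (0.40 log units; beyond the scatter). For compound 4 the estimated value is 0.4 mg/kg, with an expected range of 0.12 mg/kg to 1.2 mg/kg.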

Compound 4, dose for half-maximal effect: 0.2 mg/kg
For compound 4 the middle estimate is 2.0-fold (0.30 log units) above the measured one; the measured number falls inside the stated range.
By their numbers in this assay, from the lowest: compounds 3 and 4 (each within the scatter of the next); then compounds 1 and 2 (each within the scatter of the next).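

In this assay, 4-fluorobenzyl on the amine nitrogen also gives a clear drop from the 3-methoxybenzyl level (a 5.0-fold lower number from compound 2 to compound 4 (0.70 log units; beyond the scatter)), matching the drop seen with 4-methoxybenzyl (a 5.0-fold lower number from compound 2 to compound 3 (0.70 log units; beyond the scatter)). Fluoro in place of methoxy on an aromatic carbon then makes no difference (no change at the digits printed from compound 3 to compound 4 (within the scatter)), so at this position the lower number is not tied to a methoxy group and holds for both 4-substituted phenyl groups shown. Nothing available here explains why these two groups read alike.

Still open, from the compounds shown here alone, is whether the drop follows the place of the substituent or the group itself, which a 3-fluorophenyl would help separate. Also open, going by these compounds, is whether an unsubstituted phenyl or a 4-chlorophenyl would stay level with compound 3 and compound 4 in this assay.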